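The compounds below may be only part of what the source reports. "The series", "measured", "known", "first", "only" and "open" are said of these compounds alone.

Measured compounds:
compound 1 `Cn1cncc1C(OCc1ccc(C#N)cc1-c1ccc(F)c(Cl)c1)c1ccc(C#N)nc1` — 46 nM
compound 2 `Cn1cncc1C(OCc1ccc(C#N)nc1-c1ccccc1)c1ccc(C#N)cc1` — 19 nM

Both numbers come from a functional assay on NIH3T3 cells (Mus musculus); a lower number here means that less compound is needed, a higher number that more compound is needed for the effect. Compound 1 gives 46 nM, the higher of the two numbers. Compound 2 gives 19 nM, and the gap between the two compounds lies beyond the usual scatter. Within the data shown here, compound 1 and compound 2 differ in more than one place, so no single structural step between measured compounds is available to rest on.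

Compound 3 `Cn1cncc1C(OCc1ccc(C#N)cc1-c1cccc2ccccc12)c1ccc(C#N)nc1` has not been measured. The change from compound 1 is naphthalen-1-yl in place of 3-chloro-4-fluorophenyl on an aromatic carbon. Nothing in the measured pair speaks to an exchange of this kind. In this assay the step from compound 1 to compound 3 is expected to stay within the scatter, with no clear direction. Compound 3 is therefore estimated at 55 nM, with a range from 18 nM to 170 nM. That estimate corresponds to an expected step of a 1.2-fold higher number from compound 1 to compound 3 (0.08 log units; within the scatter).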

Compound 3, half-maximal effective concentration: 46 nM
For compound 3 the middle estimate is 1.2-fold (0.08 log units) above the measured one, and the stated range covers the measured number.
By their numbers in this assay, from the lowest: compound 2; then compounds 1 and 3 (each within the scatter of the next).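

In this assay, the aromatic carbon ortho to a large group and meta to a cyano group takes naphthalen-1-yl in place of 3-chloro-4-fluorophenyl, and the exchange gives no change at the digits printed from compound 1 to compound 3 (within the scatter) in this series. For this pair, the second six-membered aromatic ring of carbon only and the absence of the chlorine and fluorine leave the number unmoved, so this position tolerates the larger aromatic group. Nothing measured here accounts for that flat step.

On these data alone, whether this position also accepts a non-aromatic group, such as a morpholine ring or a carboxylic acid on a short chain, remains open. Compound 2, at 19 nM, differs from compound 1 and compound 3 in more than one place, so the origin of its lower number also remains unresolved.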